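The source may report more compounds than this note shows. Statements on the series, on what has been measured and on what is new or still open speak of the compounds shown alone.

Measured so far in a functional assay on MCF7 cells (Homo sapiens) for antiproliferative activity, read by MTT assay, with a stated time of 48 h; a higher number here means a weaker inhibitor, a lower number a stronger inhibitor:
Compound 1, `N#CC1=C(N)Oc2c(N)cc3nc4ccccc4nc3c2C12C(=O)N(Cc1cnnn1-c1cccc(Br)c1)c1ccccc12`, gives > 50000 nM, which is a limit of the assay.
Compound 2, `CCOc1ccc(-n2nncc2CN2C(=O)C3(C(C#N)=C(N)Oc4c(N)cc5nc6ccccc6nc5c43)c3ccccc32)cc1`, gives 26800 nM.
Compound 3, `Cc1cc(C)cc(-n2nncc2CN2C(=O)C3(C(C#N)=C(N)Oc4c(N)cc5nc6ccccc6nc5c43)c3ccccc32)c1`, gives > 50000 nM, again a limit of the assay and not a number.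

Compound 3 thus stands only at the limit, as does compound 1, a point recorded as the limit of > 50000 nM in this assay, at which 2 of the 3 values shown sit. Compound 4, `Cc1ccc(Cl)cc1-n1nncc1CN1C(=O)C2(C(C#N)=C(N)Oc3c(N)cc4nc5ccccc5nc4c32)c2ccccc21`, differs from compound 3 in one place: 5-chloro-2-methylphenyl in place of 3,5-dimethylphenyl on an aromatic nitrogen. Going by the values given here, two measured steps bear on this kind of change on the aromatic nitrogen. There was an at least 1.8-fold higher number from compound 2 to compound 3 (0.27 log units; that floor lies within the scatter), and a step that the two limits leave unreadable from compound 1 to compound 3. Both earlier aryl swaps left the number at or near the limit, so no step beyond the scatter is expected in this assay. Compound 4 is therefore expected to give 50000 nM, between 20000 nM and 120000 nM. That estimate means a number no higher from compound 3 to compound 4 (the limit leaves the size open), expected to fall within the scatter.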

Compound 4, half-maximal inhibitory concentration: 43500 nM
For compound 4 the middle estimate is 1.1-fold (0.06 log units) above the measured one, within the range that was stated.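

With compound 4, a second aryl group on the aromatic nitrogen gives a number rather than a limit in this assay and so allows one fully readable comparison, a 1.6-fold higher number from compound 2 to compound 4 (0.21 log units; within the scatter) with the 4-ethoxyphenyl group. The steps from the two limits give only floors, an at least 1.1-fold lower number from compound 3 to compound 4 (0.06 log units; that floor lies within the scatter) and an at least 1.1-fold lower number from compound 1 to compound 4 (0.06 log units; that floor lies within the scatter) and neither shows a change beyond the scatter. Compound 1 and compound 3 remain limits of the assay, not numbers: the limit of > 50000 nM in this assay, at which 2 of the 4 values shown sit.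

As far as these compounds go, whether an amine or a carboxylic acid on this phenyl ring would move the number beyond the scatter remains open.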